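This account rests on a few compounds, and the source may have more. Where it says the series, first, only, none or still open, it means among the compounds named here.

Of the compounds shown here, three built on one shared core have so far been measured in an assay on CHO cells for displacement of a labelled ligand from adenosine receptor A3 (Homo sapiens), read by scintillation counting, tested at 10 uM; a lower number here means less inhibition, a higher number more inhibition at the concentration tested (going by the name of the read-out). Compound 1 `CC(C)(C)Cc1c(-c2c(F)cccc2F)sc(N)c1C(=O)c1ccc(Cl)cc1` gives 1% in this assay, compound 2 `COc1ccc(-c2sc(N)c(C(=O)c3cccc(Cl)c3)c2CC(C)(C)C)cc1` gives 2%, and compound 3 `COc1ccc(-c2sc(N)c(C(=O)c3ccc(C)cc3)c2CC(C)(C)C)cc1` gives 5%. Compound 1 has the lowest of the three numbers, but its gaps to compound 2 and to compound 3 both lie within the usual scatter, so the three compounds cannot be told apart on these numbers. Within the data shown here, the only step between two measured compounds that differ in one place is a number 3 percentage points higher from compound 2 to compound 3 (within the scatter), which also stays within the scatter.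

Compound 4 `CC(C)(C)Cc1c(-c2ccsc2)sc(N)c1C(=O)c1ccc(Cl)cc1` differs from compound 1 in a single place: thiophen-3-yl in place of 2,6-difluorophenyl on an aromatic carbon. Among the measured compounds shown here, no measured step touches this place on the core; the one step known concerns the group on a carbonyl carbon and did not move the number beyond the scatter. Nothing in the data argues for a shift beyond the scatter here either. Compound 4 is therefore expected to give 3%, between 0% and 12%, and the step of a number 2 percentage points higher from compound 1 to compound 4 (within the scatter) is expected to stay within the scatter.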

Compound 4, a percentage reported as inhibition, at one concentration (the size of the read-out at that concentration, not a potency): 4%
Compound 4: middle estimate off by 1 percentage points, on the low side, and the stated range covers the measured number.
By their numbers in this assay, from the lowest: compounds 1, 2, 4 and 3 (each within the scatter of the next).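

Among these compounds, the change from 2,6-difluorophenyl to thiophen-3-yl is the first one seen at this aromatic carbon next to the ring sulfur, and in this assay it gives a number 3 percentage points higher from compound 1 to compound 4 (within the scatter), so the number does not leave the scatter. The earlier step concerned only the group on the carbonyl, whereas this one shows that a five-membered aromatic ring with sulfur can take the place of a fluorinated six-membered ring of carbon with no change that can be told apart in these numbers. No further measurement here speaks to the reason for this result.

The compounds shown leave open whether a different kind of group at this place, such as a carboxylic acid or a morpholine ring, would move the number beyond the scatter. They also leave open what a shorter chain, such as ethyl, would do in place of the neopentyl group.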